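The compounds below may be only part of what the source reports. "The series", "measured", "known", "first", "only" and "open" are said of these compounds alone.

Compound 1 `CCN(CC)C/C=C/C(=O)Nc1cc2c(N3CCCc4ccccc43)ncnc2cc1O[C@@H]1CCOC1` and compound 2 `O=C(/C=C/CN1CCCCC1)Nc1cc2c(N3CCCc4ccccc43)ncnc2cc1O[C@@H]1CCOC1` share one core and differ only in the amine that sits on a saturated chain carbon bound to a double-bonded chain carbon. In a functional assay on PC-3 cells (Homo sapiens) for antiproliferative activity, read by MTT assay, with a stated time of 72 h (on this read-out higher numbers stand for weaker inhibition and lower numbers for stronger inhibition), compound 1 gives 4270 nM and compound 2 gives 3630 nM; the change a 1.2-fold lower number from compound 1 to compound 2 (0.07 log units; within the scatter) is therefore too small to separate the two, and compound 2 stands within the usual scatter of compound 1 rather than apart from it. Compound 3 `CN1CCN(C/C=C/C(=O)Nc2cc3c(N4CCCc5ccccc54)ncnc3cc2O[C@@H]2CCOC2)CC1` is built in the same way, with 4-methylpiperazin-1-yl in place of piperidin-1-yl on a saturated chain carbon bound to a double-bonded chain carbon. Among the measured compounds shown here, the only measured change that bears on this is the amine swap from compound 1 to compound 2, which stayed within the scatter, so a step of similar size is expected here: a 1.0-fold lower number from compound 2 to compound 3 (0.02 log units; within the scatter), with no shift beyond the scatter in either direction. On that basis compound 3 is estimated at 3500 nM in this assay, within a range from 1500 nM to 8500 nM.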

Compound 3, half-maximal inhibitory concentration: 9450 nM
Beside the measured number, compound 3's estimate is 2.7-fold (0.43 log units) below it; the whole stated range lies below it.
By their numbers in this assay, from the lowest: compounds 2 and 1 (each within the scatter of the next); then compound 3.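

In this assay, the amine at this position does matter: 4-methylpiperazin-1-yl in place of piperidin-1-yl gives a 2.6-fold higher number from compound 2 to compound 3 (0.42 log units; beyond the scatter), and in place of diethylamino it gives a 2.2-fold higher number from compound 1 to compound 3 (0.35 log units; beyond the scatter). Both steps are modest but beyond the scatter, so while diethylamino and piperidin-1-yl could not be told apart, 4-methylpiperazin-1-yl, with its second ring nitrogen and added methyl, separates from both toward weaker inhibition. Nothing available explains this shift.

The compounds shown leave open whether the weaker inhibition goes with the second ring nitrogen or with the methyl on it; piperazin-1-yl without the methyl and morpholin-4-yl, whose ring holds an oxygen as well as a nitrogen, would help to separate the two. On these data alone, it also remains open whether a smaller amine such as dimethylamino would fall with compound 1 and compound 2 or with compound 3.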